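Chloro to bromo on the aromatic ring: expected step

The source may report more compounds than this note shows. Statements on the series, on what has been measured and on what is new or still open speak of the compounds shown alone.

Going by the values given here, compound 2 `Clc1ccc(/C=N/c2nc3ccccc3s2)cc1` gives 41.5 nM in an assay for inhibition of Dihydrofolate reductase (Bos taurus) (on this read-out higher numbers stand for weaker inhibition and lower numbers for stronger inhibition), the higher of the two numbers measured so far. Compound 1 `O=[N+]([O-])c1cccc(/C=N/c2nc3ccccc3s2)c1` gives 31.2 nM in this assay; the two values lie within the scatter of each other, so neither can be called the stronger inhibitor. Compound 3 `Brc1ccc(/C=N/c2nc3ccccc3s2)cc1` differs from compound 2 by bromo in place of chloro on an aromatic carbon. Among the compounds with values here, no measured pair shows this swap, and nothing among the measured compounds points to a shift beyond the scatter in either direction. The expected step is a 1.0-fold lower number from compound 2 to compound 3 (0.02 log units; within the scatter), small enough to stay within the scatter. For compound 3 the estimate in this assay is 40 nM, within 20 nM to 80 nM.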

Compound 3, half-maximal inhibitory concentration: 45.5 nM
Compound 3: middle estimate off by 1.1-fold (0.06 log units), on the low side; measured number inside the range.
By their numbers in this assay, from the lowest: compounds 1, 2 and 3 (each within the scatter of the next).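

Bromo in place of chloro on an aromatic carbon, para to a large group, gives a 1.1-fold higher number from compound 2 to compound 3 (0.04 log units; within the scatter) in this assay, the first measured pair for this swap. At this place, the two halogens cannot be told apart on this read-out. No measurement at hand bears on a cause for this result.

Going by these compounds, whether an amine or a carboxylic acid on the same carbon would shift the number beyond the scatter remains open. So does the outcome of fluoro or iodo there.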